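A few compounds are considered here, and "the series" means these few. Any claim that something is new, unique, unknown or untested is made for them only; others in the source may bear on it.

Measured in a functional assay on HCT-116 cells (Homo sapiens) for antiproliferative activity, read by MTT assay, with a stated time of 48 h; on this read-out lower numbers stand for stronger inhibition of growth and higher numbers for weaker inhibition of growth:
- compound 1 `CCCCCN(Cc1ccc(C(=O)NO)cc1)c1ncc(-c2ccc(C)cc2)s1`: 23300 nM
- compound 2 `CCN(Cc1ccc(C(=O)NO)cc1)c1ncc(-c2ccc(C)cc2)s1`: 6870 nM
- compound 3 `CCCCCCCCN(Cc1ccc(C(=O)NO)cc1)c1ncc(-c2ccc(C)cc2)s1`: 6500 nM

Compound 3, with its octyl chain, stands level with compound 2, as a 1.1-fold lower number from compound 2 to compound 3 (0.02 log units; within the scatter) shows, and both lie clearly under compound 1. The next structure, compound 4 `Cc1ccc(OCCCCN(Cc2ccc(C(=O)NO)cc2)c2ncc(-c3ccc(C)cc3)s2)cc1`, keeps the shared core and alters only the outer part of that chain: 4-methylphenoxy in place of butyl on a saturated chain carbon, four bonds along the chain from a nitrogen on an aromatic ring. In words, 4-methylphenoxy comes in place of butyl on a saturated chain carbon, four bonds along the chain from a nitrogen on an aromatic ring.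

Among the measured compounds shown here, the only steps that bear on this change are those among the chain variants. They are a 3.4-fold lower number from compound 1 to compound 2 (0.53 log units; beyond the scatter) and a 3.6-fold lower number from compound 1 to compound 3 (0.55 log units; beyond the scatter), both modest. The values do not follow chain length, since the pentyl chain of compound 1 goes against any steady trend across the ethyl and octyl chains of the other two. As far as these compounds go, none of the three measured compounds carries a ring on its chain, so the direct evidence is thin, and the direction of any shift in this assay stays open. The estimated step is a 1.2-fold higher number from compound 3 to compound 4 (0.09 log units; within the scatter), so no shift beyond the scatter is expected. For compound 4 the expected value is 8000 nM, with an estimated range from 2500 nM to 25000 nM.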

Compound 4, concentration for 50% growth inhibition: 580 nM
The estimate for compound 4 lay 14-fold (1.14 log units) above the measured number; measured number outside the range, below it.
By their numbers in this assay, from the lowest: compound 4; then compounds 3 and 2 (each within the scatter of the next); then compound 1.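

In this assay, the outer part of the chain on the nitrogen turns out to be a place where one change can move the number a long way, as 4-methylphenoxy in place of butyl gives an 11-fold lower number from compound 3 to compound 4 (1.05 log units; beyond the scatter) and stands beyond the scatter of both other compounds. The same holds against the shorter chains, with a 12-fold lower number from compound 2 to compound 4 (1.07 log units; beyond the scatter) and a 40-fold lower number from compound 1 to compound 4 (1.60 log units; beyond the scatter) making compound 4 the most potent of the four in this assay, and each of these steps is larger than the widest step among the three chains without a ring, which is a 3.6-fold lower number from compound 1 to compound 3 (0.55 log units; beyond the scatter) in size. No measurement shown here accounts for this gain.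

The change brings in the oxygen, the aromatic ring and its methyl group together, so the compounds shown cannot say which of them carries the shift, and a plain phenoxy or a phenyl on a chain without oxygen would be needed to separate them. Nor do they show whether other groups at the end of the chain, such as an amine or a carboxylic acid, or a longer or shorter link to the ring, would hold the number this low.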